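Butyl-to-phenyl swap carried onto a second core

The source may hold more compounds than are shown below. What is called first, only, known or untested is meant among the compounds shown, and "the series" means these compounds.

Measured compounds and their values:
compound 1, `CCCCNc1nc(NCc2ccccc2)c2ccccc2n1`, 1250 10^-6 cm/s
compound 2, `c1ccc(CNc2nc(Nc3ccccc3)nc3ccccc23)cc1`, 1480 10^-6 cm/s
compound 3, `CCCCNc1nc(NCc2ccccc2)nc2ccccc12`, 1020 10^-6 cm/s

All three numbers come from a physicochemical assay for permeability, using PAMPA, at pH 7.4; a higher number here means that the compound crosses the layer faster, a lower number that the compound crosses the layer more slowly. Compound 1 and compound 2 share one core and differ in a single place: phenyl in place of butyl on a nitrogen on an aromatic ring. That change gave a 1.2-fold higher number from compound 1 to compound 2 (0.07 log units; within the scatter), so the two values cannot be told apart within the usual scatter of this assay.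

Compound 3 carries the butyl and benzyl substituents of compound 1 on a core built from the same atoms joined differently; the difference between the two cores is not broken down here. In this assay compound 3 gives a number close to both the others, and none of the three values is separated from another beyond the scatter.

Compound 4, `c1ccc(CNc2nc(Nc3ccccc3)c3ccccc3n2)cc1`, has not yet been measured in this assay. It stands to compound 3 as compound 2 stands to compound 1: phenyl in place of butyl on a nitrogen on an aromatic ring. The place of the change is described in the same words for both pairs, so this is the same change made on the second core.

For compound 4 the step from compound 3 is expected to be a 1.2-fold higher number from compound 3 to compound 4 (0.07 log units; within the scatter), a step of about the same size as the one already seen, because a 1.2-fold higher number from compound 1 to compound 2 (0.07 log units; within the scatter) was within the scatter and the change and its place are the same. Compound 4 is therefore expected to give about 1200 10^-6 cm/s in this assay, somewhere between 750 10^-6 cm/s and 1900 10^-6 cm/s.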

Compound 4, apparent permeability: 663 10^-6 cm/s
Beside the measured number, compound 4's estimate is 1.8-fold (0.26 log units) above it; measured number below the stated range.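

In this assay, phenyl in place of butyl on a nitrogen on an aromatic ring gives a 1.5-fold lower number from compound 3 to compound 4 (0.19 log units; within the scatter) on the second core and a 1.2-fold higher number from compound 1 to compound 2 (0.07 log units; within the scatter) on the first, so on both cores the step lies within the scatter and neither pair can be told apart. Within these two pairs, then, carrying the change from one core to the other yields no step that stands clear of repeat-measurement noise, although two pairs in one read-out establish no rule for the series and do not show that the change would stay this small on a further core. Nothing available bears on what lies behind any of these values, and with steps this small the data offer no effect to explain.

From the compounds shown here alone, what a group of another kind would do on the same nitrogen stays open, for example a longer chain such as octyl, a saturated ring such as cyclohexyl, or a chain ending in a carboxylic acid or an amine. Also open, going by these compounds, is whether any such replacement would give a step beyond the scatter on either core, and whether the two cores would then respond alike.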